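The source may hold more compounds than are shown below. What is called first, only, known or untested is meant among the compounds shown, and "the series" means these compounds.

Measured so far in an assay on membranes from HEK293 cells for displacement of a labelled ligand from adenosine receptor A2b (Homo sapiens), read by scintillation counting, with a stated time of 30 min, tested at 1 uM; a lower number here means less inhibition, a higher number more inhibition at the concentration tested (going by the name of the read-out):
compound 1, `CCN(CC)C(=O)C1=C(C)NC(=O)NC1c1ccoc1`, gives 12%;
compound 2, `CC1=C(C(=O)NC(C)C)C(c2ccsc2)NC(=O)N1`, gives 3%.

Compound 2 has the lower of the two numbers, but its value lies within the usual scatter of compound 1, so the two cannot be ordered. Compound 3, `CCN(CC)C(=O)C1=C(C)NC(=O)NC1c1ccsc1`, is not yet measured. It differs from compound 2 by diethylamino in place of isopropylamino on a carbonyl carbon. For the measured compounds named here, with no measured pair showing this change, no step beyond the scatter is expected in this assay in either direction. Compound 3 is therefore estimated at 9%, within 0% to 25%, an expected step of a number 6 percentage points higher from compound 2 to compound 3 (within the scatter).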

Compound 3, a percentage reported as inhibition, at one concentration (the size of the read-out at that concentration, not a potency): 11%
Beside the measured number, compound 3's estimate is 2 percentage points below it; low and high end bracket the measured number.
By their numbers in this assay, from the lowest: compounds 2, 3 and 1 (each within the scatter of the next).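

In this assay, diethylamino in place of isopropylamino on the carbonyl carbon, which removes the amide hydrogen, gives a number 8 percentage points higher from compound 2 to compound 3 (within the scatter), so losing that hydrogen leaves no step beyond the scatter here. Thiophen-3-yl in place of furan-3-yl on the saturated ring carbon gives a number 1 percentage points lower from compound 1 to compound 3 (within the scatter), again no step beyond the scatter. Nothing measured here bears on the reason for these results.

Still open, as far as these compounds go, is whether piperidin-1-yl on the carbonyl carbon, or phenyl in place of thiophen-3-yl, would move the number beyond the scatter.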